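Mirror image of compound 2: expected clearance

A few compounds are considered here, and "the series" means these few. Any claim that something is new, unique, unknown or untested is made for them only; others in the source may bear on it.

For the measured compounds named here, in an ADME assay on the whole organism (Mus musculus, strain BALB/c) for pharmacokinetics, read by LC-MS, with a stated time of 600 min, at a dose of 20 mg/kg by the intravenous route (on this read-out lower numbers stand for slow clearance and higher numbers for fast clearance), compound 2 (`CC(C)NC[C@@H]1C[C@H](c2ccc3c(N)ncnn23)[C@@H](O)[C@H]1O`) gives 46 mL/min/kg, the lower of the two numbers so far, and compound 1 (`CN(CCCNC(=O)Nc1ccc(C(C)(C)C)cc1)C[C@H]1C[C@@H](c2ccc3c(N)ncnn23)[C@H](O)[C@@H]1O`) gives 108 mL/min/kg, a gap beyond the scatter. Compound 3 (`CC(C)NC[C@H]1C[C@@H](c2ccc3c(N)ncnn23)[C@H](O)[C@@H]1O`) is the next case: the two compounds have the same atoms and bonds and differ only in configuration as drawn: 4 of 4 stereo elements differ (all stereocentres are inverted: mirror images); a stereocentre at a saturated ring carbon is drawn S in compound 2 and R in compound 3; a stereocentre at a saturated ring carbon is drawn R in compound 2 and S in compound 3; a stereocentre at a saturated ring carbon is drawn R in compound 2 and S in compound 3; a stereocentre at a saturated ring carbon is drawn S in compound 2 and R in compound 3. Going by the values given here, no measured pair shows what a change of configuration alone does to clearance. The expected step of a 1.1-fold higher number from compound 2 to compound 3 (0.04 log units; within the scatter) therefore stays within the scatter, with no direction favoured. For compound 3 the estimated clearance is 50 mL/min/kg, with an expected range of 24 mL/min/kg to 105 mL/min/kg.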

Compound 3, clearance: 23.3 mL/min/kg
Estimate against measurement, compound 3: 2.1-fold (0.33 log units) above, outside the stated range (below it).
By their numbers in this assay, from the lowest: compounds 3 and 2 (each within the scatter of the next); then compound 1.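

For the compounds shown here, this is the first pair that isolates configuration: in this assay, inverting all stereocentres gives a 2.0-fold lower number from compound 2 to compound 3 (0.30 log units; within the scatter), so the mirror-image change leaves clearance within the scatter. The pair reads configuration alone, with nothing else to account for the values: the fact that compounds 2 and 3 differ only in the configuration as drawn.

Open, on these data alone, is whether inverting a single stereocentre, rather than all of them, would also stay within the scatter. Also open, as far as these compounds go, is how clearance responds in either mirror-image series when a carboxylic acid replaces the amine of the side chain.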